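Cytotoxicity notes on a small series and its next member

The source may hold more compounds than are shown below. What is called first, only, known or untested is meant among the compounds shown, and "the series" means these compounds.

Measured so far:
- compound 1 `Cc1ccc(NCc2cn(-c3ccccc3)nc2-c2ccc(C)cc2)cc1`: in an ADME assay on MT4 cells (Homo sapiens) for cytotoxicity, read by MTT assay, with a stated time of 96 h (a higher number here means that more compound is tolerated, a lower number that less compound is tolerated), compound 1 gives > 100000 nM, which is a limit of the assay and not a number.
- compound 2 `Cc1ccc(NCc2cn(-c3ccccc3)nc2-c2ccccc2)cc1`: in this assay compound 2 gives > 100000 nM, again a limit of the assay.
- compound 3 `Cc1ccc(NCc2cn(-c3ccccc3)nc2-c2ccc(Br)cc2)cc1`: in this assay compound 3 gives > 100000 nM, also a limit of the assay.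

All three measured values sit at the same limit, as noted in the limit of > 100000 nM in this assay, at which 3 of the 3 values shown sit. The changes among them are small: from compound 1 to compound 2 the difference is hydrogen in place of methyl on an aromatic carbon, and the step is a step that the two limits leave unreadable from compound 1 to compound 2. From compound 1 to compound 3 the difference is bromo in place of methyl on an aromatic carbon, with the step that the two limits leave unreadable from compound 1 to compound 3. Between compound 2 and compound 3 the step is a step that the two limits leave unreadable from compound 2 to compound 3. Since every value is a limit, none of these steps can be sized.

The unmeasured compound 4 `Brc1ccc(-c2nn(-c3ccccc3)cc2CNc2ccccc2)cc1` differs from compound 3 by hydrogen in place of methyl on an aromatic carbon. This is the same change already made from compound 1 to compound 2, and the place around it reads the same in both cases; the two cores differ by bromo in place of methyl on an aromatic carbon. That earlier step could not be read because both of its ends are limits.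

Compound 4 is expected to stay at the same limit, an expected step of a number no higher from compound 3 to compound 4 (the limit leaves the size open), because compound 3 gives > 100000 nM and the limit of > 100000 nM in this assay, at which 3 of the 3 values shown sit, shows all measured members there. The estimate for compound 4 is 100000 nM, expected to lie between 50000 nM and 300000 nM.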

Compound 4, half-maximal cytotoxic concentration: > 100000 nM
Compound 4 was reported as a limit; the forecaster's own chance of this, stated with the estimate: 90%; the middle value lies on the limit itself.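

In this assay compound 4 gives > 100000 nM, a limit of the assay and not a number. With compound 3 also at a limit, no new step can be read between compound 3 and compound 4, and the series stays at one limit: the limit of > 100000 nM in this assay, at which 4 of the 4 values shown sit. The compounds shown leave open how much of any of them is tolerated, and whether any change on the shared core would give a readable value.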